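A few compounds are considered here, and "the series" means these few. Any claim that something is new, unique, unknown or untested is made for them only; others in the source may bear on it.

Measured compounds:
compound 1 `CCc1ccc(/C=C/C(O)=C2/C(=O)C(C)=C(OC)C(C)(C)C2=O)cc1` — in a functional assay on 1A9 cells (Homo sapiens) for cytotoxicity (on this read-out lower numbers stand for an effect already at smaller amounts and higher numbers for an effect only at larger amounts of compound), compound 1 gives 5.3 ug/mL
compound 2 `COC1=C(C)C(=O)/C(=C(O)/C=C/c2c(C)cccc2C)C(=O)C1(C)C` — in this assay compound 2 gives "not determined" (no result reported)

Compound 1 and compound 2 share a core and differ only in the aromatic group at the end of the chain. For compound 1 a single number is known; for compound 2 no result was obtained in this assay, so compound 2 stands nowhere on the numbers shown and offers no anchor for comparison.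

Compound 3 `COC1=C(C)C(=O)/C(=C(O)/C=C/c2cccs2)C(=O)C1(C)C` is the next compound, not yet tested. It differs from compound 2 in one place: thiophen-2-yl in place of 2,6-dimethylphenyl on a double-bonded chain carbon bound to a double-bonded chain carbon. For the measured compounds named here, with no measured pair of this kind to draw on, the size and direction of this change in this assay remain open.

Taking compound 1 with its 5.3 ug/mL as the only reference in the same series, compound 3 is expected to land near it, at an estimated 6 ug/mL with a plausible range from 1.5 ug/mL to 25 ug/mL.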

Compound 3, concentration for half-maximal effect: 4 ug/mL
Estimate against measurement, compound 3: 1.5-fold (0.18 log units) above, within the range that was stated.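

For the compounds shown here, replacing 4-ethylphenyl with thiophen-2-yl on a double-bonded chain carbon bound to a double-bonded chain carbon gives, in this assay, a 1.3-fold lower number from compound 1 to compound 3 (0.12 log units; within the scatter), the first readable step at this position. It shows that two quite different aromatic end groups, one of them a five-membered ring with sulfur, can occupy this place with no difference beyond the scatter. The step from compound 2 to compound 3 cannot be read, as compound 2 has no number, and no supporting data offer an explanation for the similar values of compound 1 and compound 3.

This single step cannot show how far that tolerance extends. As far as these compounds go, whether a non-aromatic group at this place, such as an amine, a carboxylic acid or a longer alkyl chain, would shift the read-out remains open.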